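Moving the Chlorine on the Benzyl Ring

This account rests on a few compounds, and the source may have more. Where it says the series, first, only, none or still open, it means among the compounds named here.

Compound 1 `O=C(OCc1ccccc1)N1CCN(C(=S)SCc2cn(Cc3ccc(Cl)cc3)nn2)CC1` was tested in a functional assay on MGC-803 cells (Homo sapiens) for inhibition, read by MTT assay, with a stated time of 72 h (a lower number here means a stronger inhibitor, a higher number a weaker inhibitor), where compound 1 gives 31300 nM. Of the two numbers in hand this is the higher one, yet compound 2 `COc1cc(Cn2cc(CSC(=S)N3CCN(C(=O)OC(C)(C)C)CC3)nn2)cc(OC)c1OC` sits right beside it: in this assay compound 2 gives 27300 nM, a gap within the usual scatter, so the two cannot be told apart. For compound 3 `S=C(SCc1cn(Cc2ccc(Cl)cc2)nn1)N1CCNCC1` the entry in this assay reads "not determined" (no result reported), so no number is in hand for it. The new entry is compound 4 `O=C(OCc1ccccc1)N1CCN(C(=S)SCc2cn(Cc3ccccc3Cl)nn2)CC1`, which keeps every atom of compound 1 and changes only how they are joined: 2-chlorophenyl in place of 4-chlorophenyl on a saturated chain carbon bound to an aromatic nitrogen. Among the measured compounds shown here, no measured pair in this set shows what such a move does, so nothing here supports expecting a shift beyond the scatter in either direction. The expected step is a 1.0-fold lower number from compound 1 to compound 4 (0.02 log units; within the scatter), small and within the scatter. For compound 4 the estimate is 30000 nM, with a range from 12000 nM to 80000 nM.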

Compound 4, half-maximal inhibitory concentration: 15500 nM
For compound 4 the middle estimate is 1.9-fold (0.29 log units) above the measured one, and the stated range covers the measured number.
By their numbers in this assay, from the lowest: compounds 4, 2 and 1 (each within the scatter of the next, the first and the last beyond it).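

In this assay, where the chlorine sits on the benzyl ring matters: going from 4-chlorobenzyl to 2-chlorobenzyl brings a 2.0-fold lower number from compound 1 to compound 4 (0.31 log units; beyond the scatter), a modest step with no atom gained or lost. Among the compounds shown here, this is the first pair here that differs in one place, so it gives the first direct reading of this position. Nothing measured on these compounds explains the step.

Still open, on these data alone, is whether a plain benzyl group, or a bromine in place of the chlorine, would read differently. Also open, as far as these compounds go, is whether the same move gives a similar step on a different carbamate.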